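The source may hold more compounds than are shown below. What is called first, only, known or untested is meant among the compounds shown, and "the series" means these compounds.

Compound 1 `CCCCCCCCCCCCCC[C@@H](O)[C@@H](O)[C@H](CO)n1cc(CCCCCC)nn1` gives 13700 nM in a functional assay on NCI-H358 cells (Homo sapiens) for cytotoxicity, read by sulforhodamine B assay; on this read-out lower numbers stand for an effect already at smaller amounts and higher numbers for an effect only at larger amounts of compound.
Compound 2 `CCCCCCCCCCCCC/C=C/[C@@H](O)[C@H](CO)n1cc(CCCC)nn1` gives 13600 nM in this assay.
Compound 3 `CCCCCCCCCCCCC/C=C/[C@@H](O)[C@H](CO)n1cc(CCC)nn1` gives 15700 nM in this assay.

On these three numbers compound 1 holds the second highest place, though compound 2 and compound 3 both sit within the usual scatter of it, so no order among the three can be read. Compound 4 `CCCCCCCCCCCCCC[C@@H](O)[C@@H](O)[C@H](CO)n1cc(CCC)nn1` differs from compound 1 in one place: hydrogen in place of propyl on a saturated chain carbon, three bonds along the chain from an aromatic carbon. For the measured compounds named here, the only measured step that bears on this is a 1.2-fold higher number from compound 2 to compound 3 (0.06 log units; within the scatter), where a smaller piece is removed at the same place and the number does not move beyond the scatter. Shortening by a longer piece here is therefore expected to leave this assay essentially unchanged, with no step beyond the scatter, and the expected step is a 1.1-fold higher number from compound 1 to compound 4 (0.04 log units; within the scatter). Compound 4 is thus estimated at 15000 nM, within a range from 8000 nM to 30000 nM.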

Compound 4, half-maximal effective concentration: 13200 nM
Beside the measured number, compound 4's estimate is 1.1-fold (0.06 log units) above it; low and high end bracket the measured number.
By their numbers in this assay, from the lowest: compounds 4, 2, 1 and 3 (each within the scatter of the next).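

Going from hexyl to propyl gives a 1.0-fold lower number from compound 1 to compound 4 (0.02 log units; within the scatter) in this assay. The earlier step covered only a smaller cut at this place, on a different core, so this result extends the same flat reading to a longer piece on the core of compound 1. Nothing available explains this flat reading.

The compounds shown leave open whether a chain longer than hexyl, or an amine or a carboxylic acid at the end of this chain, would take the number beyond the scatter.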